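Nonyl for Arylsulfonylamino on a Weakly Antiproliferative Core

This account rests on a few compounds, and the source may have more. Where it says the series, first, only, none or still open, it means among the compounds named here.

Two compounds of the series carry numbers in a functional assay on CFPAC-1 cells (Homo sapiens) for antiproliferative activity, read by MTT assay, with a stated time of 72 h; a higher number here means a weaker inhibitor, a lower number a stronger inhibitor. Compound 1 `O=C1O[C@H]([C@@H](O)Cn2cc(CNS(=O)(=O)c3ccc(Cl)cc3F)nn2)C(OCc2ccccc2)=C1OCc1ccccc1` gives 58200 nM in this assay. Compound 2 `O=C1O[C@H]([C@@H](O)Cn2cc(-c3cc(C(F)(F)F)cc(C(F)(F)F)c3)nn2)C(OCc2ccccc2)=C1OCc1ccccc1` gives 66500 nM in this assay. Compound 1 holds the lower of the two numbers, but its gap to compound 2 lies within the usual scatter, so the two cannot be ordered and both count as weak inhibitors.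

Compound 3 `CCCCCCCCCCc1cn(C[C@H](O)[C@H]2OC(=O)C(OCc3ccccc3)=C2OCc2ccccc2)nn1` has no number yet in this assay. It differs from compound 1 in one place: nonyl in place of ((4-chloro-2-fluorophenyl)sulfonyl)amino on a saturated chain carbon bound to an aromatic carbon. Going by the values given here, no step between measured compounds is available to calibrate a change of this kind; the only comparison on hand is between compound 1 and compound 2, whose numbers agree within the scatter although the groups on their shared core differ considerably. On that basis the change is expected to be small, a 1.3-fold lower number from compound 1 to compound 3 (0.11 log units; within the scatter), most likely a move toward a lower number that does not clearly exceed the scatter. Compound 3 is accordingly estimated at 45000 nM in this assay, with a range from 15000 nM to 130000 nM.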

Compound 3, half-maximal inhibitory concentration: 40300 nM
Compound 3: the middle estimate sits 1.1-fold (0.05 log units) above what was measured; measured number inside the range.
By their numbers in this assay, from the lowest: compounds 3, 1 and 2 (each within the scatter of the next).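

In this assay, going by these compounds alone, the step at this position, on a saturated chain carbon bound to an aromatic carbon, is a 1.4-fold lower number from compound 1 to compound 3 (0.16 log units; within the scatter): the first reading of a single change at this place. The change is a large one in what is counted: ((4-chloro-2-fluorophenyl)sulfonyl)amino, with its six-membered aromatic ring, 1 hydrogen-bond donor and 2 hydrogen-bond acceptors, leaves, and nonyl, with no ring, donor or acceptor, enters, yet the two numbers cannot be told apart, so in this pair neither the aromatic ring, the donor nor the acceptors of the leaving group are needed to hold the number at the level of compound 1. No separate measurement on hand bears on why this pair agrees.

The compounds shown leave open whether any group at this place can move the number beyond the scatter, since this one step stays within it. An amine, a carboxylic acid or a longer chain in place of nonyl would test whether the number at this position responds at all.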